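Isopropyl for dimethoxypropyl on a purine-like core

A few compounds are considered here, and "the series" means these few. Any claim that something is new, unique, unknown or untested is made for them only; others in the source may bear on it.

Of the compounds shown here, two with a benzamide-bearing aromatic amine have been measured in a functional assay on NCI-H460 cells (Homo sapiens) for antiproliferative activity, read by CCK-8 assay, with a stated time of 72 h, tested at 2 uM; a lower number here means a weaker effect, a higher number a stronger effect of the compound at the concentration tested. Compound 1 `COC(CCn1cnc2c(NCc3ccc(C(=O)Nc4ccccc4N)cc3)nc(Cl)nc21)OC` gives 43.7% there, the higher of the two numbers. Compound 2 `Nc1ccccc1NC(=O)/C=C/c1ccc(COCNc2nc(Nc3cccc(Cl)c3)c3ncn(C4CCCC4)c3n2)cc1` gives 37.1% in this assay, a number that lies within the scatter of compound 1, so the two cannot be ordered against each other.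

Compound 3 `CC(C)n1cnc2c(NCc3ccc(C(=O)Nc4ccccc4N)cc3)nc(Cl)nc21` is not yet measured in this assay. It differs from compound 1 in one place: isopropyl in place of 3,3-dimethoxypropyl on an aromatic nitrogen. Going by the values given here, no measured pair shows what this kind of exchange does, so no step size is known from the data.

With only compound 1 as a footing, compound 3 is expected to land near it, with the estimated step of a number 1.3 percentage points higher from compound 1 to compound 3 (within the scatter) amounting to no change beyond the scatter. In this assay compound 3 is estimated at 45%, within a range from 25% to 65%.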

Compound 3, a percentage reported as inhibition, at one concentration (the size of the read-out at that concentration, not a potency): 54.2%
Compound 3: the middle estimate sits 9.2 percentage points below what was measured; low and high end bracket the measured number.
By their numbers in this assay, from the lowest: compounds 2 and 1 (each within the scatter of the next); then compound 3.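

In this assay, the exchange of 3,3-dimethoxypropyl for isopropyl on the aromatic nitrogen gives a number 10.5 percentage points higher from compound 1 to compound 3 (beyond the scatter), which shows that the read-out responds to the group at this position and that the smaller isopropyl is accepted there. The step is modest, and because the exchange removes the two oxygens and shortens the group at once, this single pair cannot separate those two changes. Nothing in the data shown explains the step.

From the compounds shown here alone, it remains open whether a plain propyl chain, a methyl group, or a chain ending in an amine or a carboxylic acid would move the read-out further in either direction. Going by these compounds, since these numbers come from one concentration, it is also open whether the step reflects a difference in potency.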